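Secondary versus tertiary amine in a chlorobiaryl series

A few compounds are considered here, and "the series" means these few. Any claim that something is new, unique, unknown or untested is made for them only; others in the source may bear on it.

Measured compounds:
- compound 1 `COc1ccccc1-c1cc(C2CCNC2)ccc1Cl` gives 410 nM in an assay on isolated protein for binding affinity to 5-hydroxytryptamine receptor 1B (Homo sapiens); a lower number here means a stronger inhibitor, a higher number a weaker inhibitor
- compound 2 `CCNCc1ccc(Cl)c(-c2ccccc2OC)c1` gives 210 nM in this assay
- compound 3 `CCN(CC)Cc1ccc(Cl)c(-c2ccccc2OC)c1` gives only a limit, > 10000 nM, in this assay

Compound 3 sits at the limit of this assay; its value is not a number but the upper bound the assay reports (the limit of > 10000 nM in this assay, at which 1 of the 3 values shown sits). Among the three measured compounds, compound 1 and compound 2 differ by a 2.0-fold lower number from compound 1 to compound 2 (0.29 log units; within the scatter), while the tertiary amine stands apart: an at least 24-fold higher number from compound 1 to compound 3 (1.38 log units; beyond the scatter) and an at least 47-fold higher number from compound 2 to compound 3 (1.67 log units; beyond the scatter).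

Compound 4 `CCCNCc1ccc(Cl)c(-c2ccccc2OC)c1` is the unmeasured member. The change from compound 3 is propylamino in place of diethylamino on a saturated chain carbon bound to an aromatic carbon; read one bond further out, a (diethylamino)methyl group becomes a (propylamino)methyl group, so a hydrogen-bond donor on the amine nitrogen is restored, as in compound 2.

The step that bears most directly on this is the large rise seen for an at least 47-fold higher number from compound 2 to compound 3 (1.67 log units; beyond the scatter), the reverse of the present change in the sense of donor count; an at least 24-fold higher number from compound 1 to compound 3 (1.38 log units; beyond the scatter) points the same way. Compound 4 is therefore expected to return toward the range of compound 1 and compound 2, with an at least 33-fold lower number from compound 3 to compound 4 (1.52 log units; beyond the scatter) as the expected size of the move. For compound 4 the estimate is 300 nM, between 90 nM and 2000 nM.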

Compound 4, inhibition constant: 640 nM
Estimate against measurement, compound 4: 2.1-fold (0.33 log units) below; the range from low to high includes it.
By their numbers in this assay, from the lowest: compounds 2, 1 and 4 (each within the scatter of the next, the first and the last beyond it). At a limit, above all of these: compound 3.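

Propylamino in place of diethylamino gives an at least 15-fold lower number from compound 3 to compound 4 (1.19 log units; beyond the scatter) in this assay, so compound 2 is no longer the only secondary amine in this group of open-chain amines that stands apart from the tertiary amine. On these data alone, the full size of that step stays unknown, since compound 3 gives a limit and not a number: the limit of > 10000 nM in this assay, at which 1 of the 4 values shown sits. Chain length on the secondary amine also registers, on a smaller scale, with methyl in place of hydrogen on the saturated chain giving a 3.0-fold higher number from compound 2 to compound 4 (0.48 log units; beyond the scatter), whereas the change from the ring amine gives a 1.6-fold higher number from compound 1 to compound 4 (0.19 log units; within the scatter), so (propylamino)methyl and pyrrolidin-3-yl cannot be told apart here.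

The compounds shown hold a single tertiary amine, so they do not separate a loss tied to any tertiary amine from one tied to diethylamino itself; a dimethylamino group on the same saturated chain carbon would bear on this. As far as these compounds go, how the value moves beyond ethylamino and propylamino also stays open, and methylamino and butylamino groups would extend that short comparison in both directions.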